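Cyano for Carbamoyl on Two Fused Cores

The source may report more compounds than this note shows. Statements on the series, on what has been measured and on what is new or still open speak of the compounds shown alone.

Compound 1 `CC(C)(C)c1ccc(Cn2cc(C(N)=O)c3c(N)ncnc32)cc1` and compound 2 `CC(C)(C)c1ccc(Cn2cc(C#N)c3c(N)ncnc32)cc1` share one core. In a functional assay on KB cells (Homo sapiens) for cytotoxicity (on this read-out lower numbers stand for stronger inhibition and higher numbers for weaker inhibition), compound 1 gives 900 nM, and compound 2 gives 3000 nM in this assay. Their difference, (cyano in place of carbamoyl on an aromatic carbon), produced a 3.3-fold higher number from compound 1 to compound 2 (0.52 log units; beyond the scatter). Compound 3 `Cc1ccccc1Cn1cc(C(N)=O)c2c(N)ncnc21` carries another core; the difference between the two cores is not broken down here. In this assay compound 3 reaches only a limit, > 100000 nM, namely (the limit of > 100000 nM in this assay, at which 1 of the 3 values shown sits). Compound 4 `Cc1ccccc1Cn1cc(C#N)c2c(N)ncnc21` differs from compound 3 by cyano in place of carbamoyl on an aromatic carbon. This is the same kind of change as from compound 1 to compound 2, except that there the ring atom bears a large group, here a group of 8 heavy atoms. Because that change gave a 3.3-fold higher number from compound 1 to compound 2 (0.52 log units; beyond the scatter), compound 4 is expected to remain at the limit, with an estimated step that the limit leaves unreadable from compound 3 to compound 4. Compound 4 is estimated at 300000 nM, between 100000 nM and 1000000 nM.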

Compound 4, half-maximal inhibitory concentration: > 100000 nM
Compound 4 ended at the assay's limit; the forecaster's own chance of this, stated with the estimate: 90%; the middle value lies beyond the limit too.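

Within the data shown here, compound 3 and compound 4 both sit at a limit in this assay, and no step between them can be read. The compounds shown leave open whether cyano in place of carbamoyl changes the number on the core of compound 3.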